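From a Nonyl Chain to a Methoxyphenyl Group

The compounds below may be only part of what the source reports. "The series", "measured", "known", "first", "only" and "open" are said of these compounds alone.

Compound 3 `CCCCCCCCCCn1c(=O)n(C2OC(CO)[C@@H](O)[C@H]2O)c2nc(N)nc(O)c21` gives the lowest number of the three measured compounds: in a functional assay on the whole organism (B cells) with Mus musculus as the target (on this read-out lower numbers stand for smaller maximal responses and higher numbers for larger maximal responses), compound 3 gives 0%. Compound 1 `NCC(O)Cn1c(=O)n(C2OC(CO)[C@@H](O)[C@H]2O)c2nc(N)nc(O)c21` gives 110% and compound 2 `Nc1nc(O)c2c(n1)n(C1OC(CO)[C@@H](O)[C@H]1O)c(=O)n2CC(O)CSc1ccccc1` gives 12%. The steps down to compound 3 were a number 110 percentage points lower from compound 1 to compound 3 (beyond the scatter) and a number 12 percentage points lower from compound 2 to compound 3 (beyond the scatter). Compound 4 `COc1ccc(Cn2c(=O)n(C3OC(CO)[C@@H](O)[C@H]3O)c3nc(N)nc(O)c32)cc1` differs from compound 3 by 4-methoxyphenyl in place of nonyl on a saturated chain carbon bound to an aromatic nitrogen. The step of a number 15 percentage points higher from compound 3 to compound 4 (beyond the scatter) is expected to be small and upward, because compound 2 with its phenylsulfanyl chain gives only 12%. Compound 4 is therefore expected to give 15%, with a range from 0% to 50%.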

Compound 4, largest response reached (reported as maximal response), in percent of the reference or control that the assay uses: 44%
Compound 4: middle estimate off by 29 percentage points, on the low side; the range from low to high includes it.
By their numbers in this assay, from the lowest: compound 3; then compound 2; then compound 4; then compound 1.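

An aromatic ring at this position keeps part of the response that the nonyl chain loses, with a number 44 percentage points higher from compound 3 to compound 4 (beyond the scatter). Having an aromatic ring is not enough to set the response, as the phenylsulfanyl chain also carries one, and the change gives a number 32 percentage points higher from compound 2 to compound 4 (beyond the scatter), while the chain with the amino group stays ahead, with a number 66 percentage points lower from compound 1 to compound 4 (beyond the scatter). Nothing measured here explains these steps.

As far as these compounds go, it remains open what the methoxy group itself contributes, which a plain benzyl group would show. From the compounds shown here alone, it is also open whether an amine on the ring would restore the full response.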